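Cyclohexyl replacement at the aminobenzimidazole nitrogen of compound 1

The compounds below may be only part of what the source reports. "The series", "measured", "known", "first", "only" and "open" are said of these compounds alone.

Three compounds of this series have numbers in an assay on CHO-K1 cells for displacement of a labelled ligand from melanin-concentrating hormone receptor 1 (Homo sapiens), read by scintillation counting; on this read-out lower numbers stand for stronger inhibition and higher numbers for weaker inhibition. Compound 1 `CC(=O)N1CCC(N(C)c2nc3ccc(NC(=O)CCc4ccc(C(F)(F)F)cc4)cc3[nH]2)C1` gives 30 nM in this assay. Compound 3 `CC(C)N(C)c1nc2ccc(NC(=O)c3cnc(-c4ccc(F)cc4)cn3)cc2[nH]1` gives 2.7 nM, and compound 2 `CC(C)N(C)c1ccc2nc(NC(=O)CCc3ccc(C(F)(F)F)cc3)ccc2n1` gives 375 nM. Compound 1 therefore holds the second highest of the three numbers: its gap to compound 3 and its gap to compound 2 are both beyond the scatter, so compound 1 sits between the two, and the three structures differ in more than one place, so no single change can be read from them.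

Compound 4 `CN(c1nc2ccc(NC(=O)CCc3ccc(C(F)(F)F)cc3)cc2[nH]1)C1CCCCC1` is not yet measured. It differs from compound 1 in one place: cyclohexyl in place of 1-acetylpyrrolidin-3-yl on a nitrogen on an aromatic ring. The amide side chain and the core of compound 1 are kept. For the measured compounds named here, no measured pair shows this change, so the size of the step is open.

The expectation is that the step from compound 1 to compound 4 in this assay, a 1.2-fold higher number from compound 1 to compound 4 (0.07 log units; within the scatter), stays within the scatter, with no direction favoured. Compound 4 is estimated at 35 nM, within a range of 10 nM to 150 nM.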

Compound 4, half-maximal inhibitory concentration: 6.7 nM
Compound 4: the middle estimate sits 5.2-fold (0.72 log units) above what was measured; measured number below the stated range.
By their numbers in this assay, from the lowest: compound 3; then compound 4; then compound 1; then compound 2.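

In this assay, cyclohexyl in place of 1-acetylpyrrolidin-3-yl on a nitrogen on an aromatic ring gives a 4.5-fold lower number from compound 1 to compound 4 (0.65 log units; beyond the scatter), a modest step beyond the scatter. For the compounds shown here, this is the first reading of this position with all else held constant: the number responds to the group placed here, and the hydrogen-bond acceptor of 1-acetylpyrrolidin-3-yl is not required for a number in this range, since a carbon-only ring with no hydrogen-bond acceptor also gives one. No supporting evidence is available to account for the step, so it cannot be assigned to any one part of the change.

The compounds shown leave open how the number responds to cyclopentyl, or to a pyrrolidin-3-yl carrying a free amine, on this same nitrogen. They also leave open whether the step carries over to other amide side chains.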